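Aryl swap at the saturated ring carbon: furan to thiophene

The compounds below may be only part of what the source reports. "The series", "measured", "known", "first", "only" and "open" are said of these compounds alone.

Measured compounds:
compound 1 `CC1=C(C(=O)C2CC2)C(c2ccco2)NC(=O)N1`, 2%
compound 2 `CCCC(=O)C1=C(C)NC(=O)NC1c1ccco1`, 1%
compound 3 `CC1=C(C(=O)CC(C)C)C(c2ccco2)NC(=O)N1`, 16%

In an assay on membranes from CHO cells for displacement of a labelled ligand from adenosine receptor A1 (Homo sapiens), read by scintillation counting, with a stated time of 60 min, tested at 1 uM (a lower number here means less inhibition, a higher number more inhibition at the concentration tested (going by the name of the read-out)), compound 1 stands second highest of the three numbers. Compound 2 lies nearest to it, with a number 1 percentage points lower from compound 1 to compound 2 (within the scatter). Compound 3 lies furthest, with a number 14 percentage points higher from compound 1 to compound 3 (beyond the scatter). Going by the values given here, the only change that moves the read-out beyond the scatter is on the carbonyl side: a number 15 percentage points higher from compound 2 to compound 3 (beyond the scatter).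

Compound 4 `CC1=C(C(=O)C2CC2)C(c2ccsc2)NC(=O)N1` differs from compound 1 in one place: thiophen-3-yl in place of furan-2-yl on a saturated ring carbon. Among the compounds with values here, none of the measured steps touches this position; the measured steps vary only the group on the carbonyl carbon, and every measured compound carries furan-2-yl on the saturated ring carbon. Within the data shown here, there is therefore no step to draw on for the size of this change. Given that compound 1 gives 2% and that nothing measured suggests the aryl group at this position is decisive, the expectation is a step of a number 2 percentage points higher from compound 1 to compound 4 (within the scatter), not beyond the scatter, in no particular direction. Compound 4 is estimated at 4%, with a range from 0% to 15%.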

Compound 4, a percentage reported as inhibition, at one concentration (the size of the read-out at that concentration, not a potency): 2%
Compound 4: the middle estimate sits 2 percentage points above what was measured, and the stated range covers the measured number.
By their numbers in this assay, from the lowest: compounds 2, 1 and 4 (each within the scatter of the next); then compound 3.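

In this assay, going by these compounds alone, this is the first step that leaves the carbonyl side untouched and changes the group on the saturated ring carbon: no change at the digits printed from compound 1 to compound 4 (within the scatter). On the cyclopropylcarbonyl background, thiophen-3-yl therefore reads the same as furan-2-yl within the scatter, but compound 1 gives only 2%, so a fall in inhibition would hardly show here and the step says little about this position where the read-out is higher. No measurement bears on why the swap leaves the number where it is.

Within the data shown here, still open is whether the same swap would read alike with the isobutyl group of compound 3, which gives 16% and is the only carbonyl variant whose step from compound 1 lies beyond the scatter. Also open is how this saturated ring carbon would respond to groups further from the two five-membered aromatic rings shown, such as a phenyl ring, a phenyl ring carrying an amine, or a saturated cyclohexyl ring.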